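A few compounds are considered here, and "the series" means these few. Any claim that something is new, unique, unknown or untested is made for them only; others in the source may bear on it.

Of the compounds shown here, three sharing one core have been tested in an assay on HEK293 cells for inhibition of transient receptor potential cation channel subfamily V member 6 (Homo sapiens), read by FLIPR and calcium flux, with a stated time of 5 min; a higher number here means a weaker inhibitor, a lower number a stronger inhibitor. Compound 1 `Fc1ccc([B-]2(c3ccccc3)[NH2+]CCO2)cc1` gives 18800 nM in this assay. Compound 2 `Cc1ccc([B-]2(c3ccccc3)[NH2+]CCO2)cc1` gives 18900 nM. Compound 3 `CCCCc1ccc([B-]2(c3ccccc3)[NH2+]CCO2)cc1` gives 14300 nM, the lowest of the three numbers, though its gaps to both others sit within the scatter, so the three cannot be told apart. Compound 4 `c1ccc(-c2ccc([B-]3(c4ccccc4)[NH2+]CCO3)cc2)cc1` has not yet been measured; it differs from compound 3 by phenyl in place of butyl on an aromatic carbon. Going by the values given here, the steps that bear on this all changed the group on the same aromatic carbon: a 1.0-fold higher number from compound 1 to compound 2 (0.00 log units; within the scatter), a 1.3-fold lower number from compound 1 to compound 3 (0.12 log units; within the scatter) and a 1.3-fold lower number from compound 2 to compound 3 (0.12 log units; within the scatter). Among the compounds with values here, none of them moved the number beyond the scatter, and none put a phenyl in that place, so the new change has no direct precedent; what the three steps show is that this position has so far tolerated different groups without a shift in the number. The expected step is a 1.2-fold lower number from compound 3 to compound 4 (0.08 log units; within the scatter), which is within the scatter. Compound 4 is estimated at 12000 nM, with a range from 4000 nM to 35000 nM.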

Compound 4, half-maximal inhibitory concentration: 72300 nM
The estimate for compound 4 lay 6.0-fold (0.78 log units) below the measured number; measured number outside the range, above it.
By their numbers in this assay, from the lowest: compounds 3, 1 and 2 (each within the scatter of the next); then compound 4.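

In this assay, this position proves not to be indifferent to the group it carries: the change to phenyl gives a 5.1-fold higher number from compound 3 to compound 4 (0.70 log units; beyond the scatter), along with a 3.8-fold higher number from compound 2 to compound 4 (0.58 log units; beyond the scatter) and a 3.8-fold higher number from compound 1 to compound 4 (0.58 log units; beyond the scatter). Fluoro, methyl and butyl could not be told apart, so phenyl, the only one of these four groups with a ring, is the first to move the number beyond the scatter, and compound 4 is the weakest inhibitor of the four. Nothing available here bears on why the number rose.

Going by these compounds alone, with only one ring-bearing group at this carbon, it remains open whether the rise belongs to phenyl alone or would also come with a cyclohexyl or pyridyl ring. Also open, from the compounds shown here alone, is whether any group, such as an amine or a carboxylic acid, could lower the number beyond the scatter.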